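The compounds below may be only part of what the source reports. "The series", "measured", "known", "first", "only" and "open" are said of these compounds alone.

Of the compounds shown here, three have so far been measured in an assay on isolated protein for displacement of a labelled ligand from metabotropic glutamate receptor 5 (Homo sapiens), with a stated time of 60 min, tested at 1 uM; a lower number here means less inhibition, a higher number more inhibition at the concentration tested (going by the name of the read-out). Compound 1 `Cc1ccc(S(=O)(=O)c2cnc3c(F)cccc3c2N2CCC(C)CC2)cc1` gives 93%, compound 2 `COc1ccc(S(=O)(=O)c2cnc3cc(F)ccc3c2N2CCC(C)CC2)cc1OC` gives 83%, and compound 3 `NS(=O)(=O)N1CCN(c2c(S(=O)(=O)c3cc(F)cc(F)c3)cnc3cc(F)ccc23)CC1` gives 6.4%. Compound 2 thus stands second of the three, its number within the usual scatter of compound 1 and far beyond the scatter from the much lower compound 3. Compound 4 `CC1CCN(c2c(S(=O)(=O)c3ccccc3)cnc3cc(F)ccc23)CC1` is not yet measured and differs from compound 2 in one place: phenyl in place of 3,4-dimethoxyphenyl on a sulfonyl sulfur. For the measured compounds named here, no measured pair shows this change alone, so its size is open. Because compound 1 gives 93% with a different ring on that sulfonyl sulfur, a modest drop at most seems plausible. Compound 4 is expected to give about 78%, between 55% and 95%. That estimate means an expected step of a number 5 percentage points lower from compound 2 to compound 4 (within the scatter), likely within the scatter.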

Compound 4, a percentage reported as inhibition, at one concentration (the size of the read-out at that concentration, not a potency): 87%
Compound 4: middle estimate off by 9 percentage points, on the low side, and the stated range covers the measured number.
By their numbers in this assay, from the lowest: compound 3; then compounds 2, 4 and 1 (each within the scatter of the next).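

In this assay, 3,4-dimethoxyphenyl on the sulfonyl sulfur can be exchanged for plain phenyl with a step of a number 4 percentage points higher from compound 2 to compound 4 (within the scatter). For the compounds shown here, this is the first matched pair at this position, and it shows that the read-out does not separate these two groups, so the two methoxy groups are not needed to keep this level of inhibition here. Nothing available explains this result. The compounds shown leave open whether a phenyl carrying a carboxylic acid or an amine would behave alike. They also leave open what a saturated ring such as cyclohexyl would do on that sulfur.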